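Aromatic-carbon substituent and acid dissociation in the diamine series

The compounds below may be only part of what the source reports. "The series", "measured", "known", "first", "only" and "open" are said of these compounds alone.

Compound 1 `COc1ccc(Oc2ccc3c(NCCCNCc4cc(F)ccc4OC)ccnc3c2)cc1` carries 4-methoxyphenoxy on an aromatic carbon of the shared core; in a physicochemical assay for acid dissociation, compound 1 gives 9.28. Compound 2 `COc1ccc(F)cc1CNCCCNc1ccnc2cc(Cc3cc(C)cc(C)c3)ccc12` carries 3,5-dimethylbenzyl on that aromatic carbon, and in this assay compound 2 gives 9.47. Compound 3 `COc1ccc(F)cc1CNCCCNc1ccnc2cc(C3CCCCC3)ccc12` carries cyclohexyl on that aromatic carbon, and in this assay compound 3 gives 9.47. The measured steps are a number 0.19 log units higher from compound 1 to compound 2 (within the scatter), a number 0.19 log units higher from compound 1 to compound 3 (within the scatter) and no change at the digits printed from compound 2 to compound 3 (within the scatter). Compound 3 therefore sits at the same digits as compound 2, with compound 1 the furthest of the three numbers from it, and no gap among the three exceeds the scatter.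

Compound 4 `COc1ccc(F)cc1CNCCCNc1ccnc2cc(CCC(C)C)ccc12` is the next member of the series. isopentyl in place of cyclohexyl on an aromatic carbon All three steps that exchanged the group on this aromatic carbon stayed within the scatter, so the step of a number 0.02 log units lower from compound 3 to compound 4 (within the scatter) is expected to be none beyond the scatter, neither clearly higher nor clearly lower. Compound 4 is accordingly estimated at 9.45 in this assay, with a range from 9.15 to 9.75.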

Compound 4, acid dissociation constant: 9.47
Estimate against measurement, compound 4: 0.02 log units below; measured number inside the range.
By their numbers in this assay, from the lowest: compounds 1, 2, 3 and 4 (each within the scatter of the next).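

Among the four groups on this aromatic carbon, isopentyl alone carries no ring, and in this assay exchanging the six-membered carbon ring of cyclohexyl for this open chain gives no change at the digits printed from compound 3 to compound 4 (within the scatter) and so shows no measurable dependence on that ring. The comparison with the two larger ring-bearing groups reads the same way, with no change at the digits printed from compound 2 to compound 4 (within the scatter) where isobutyl takes the place of 3,5-dimethylphenyl on the saturated chain carbon bound to the aromatic carbon, and a number 0.19 log units higher from compound 1 to compound 4 (within the scatter) where isopentyl takes the place of 4-methoxyphenoxy. No evidence accompanies these numbers that could account for them.

Whether an amine or a carboxylic acid on this aromatic carbon would give a step beyond the scatter in this assay remains open, since the groups compared here are limited to the four shown. Also open, going by these compounds, is whether a change in the propyl diamine chain itself, such as a longer chain between the two nitrogens, would move the number where these exchanges on the aromatic carbon do not.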